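Lengthening one side chain on compound 3

The source may report more compounds than this note shows. Statements on the series, on what has been measured and on what is new or still open speak of the compounds shown alone.

- compound 1 `COCCO[C@H](CC=C(C)C)C1=CC(=O)c2c(O)ccc(O)c2C1=O`: 62400 nM
- compound 2 `CC(C)=CC[C@@H](OCC(C)O)C1=CC(=O)c2c(O)ccc(O)c2C1=O`: 24700 nM
- compound 3 `CC[C@@](C)(O)CC(=O)O[C@H](CC=C(C)C)C1=CC(=O)c2c(O)ccc(O)c2C1=O`: 17900 nM

In a functional assay on HeLa cells (Homo sapiens) for cytotoxicity, read by MTT assay (a higher number here means a weaker inhibitor, a lower number a stronger inhibitor), compound 3 shares the low end of the range with one other compound, and the gap is within the scatter: a 1.4-fold lower number from compound 2 to compound 3 (0.14 log units; within the scatter). The remaining compound stands clearly apart: a 3.5-fold lower number from compound 1 to compound 3 (0.54 log units; beyond the scatter).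

Compound 4 `CCCCC(C)(O)CC(=O)O[C@H](CC=C(C)C)C1=CC(=O)c2c(O)ccc(O)c2C1=O` keeps the shared core and changes one group: 1-hydroxy-1-methylpentyl in place of 1-hydroxy-1-methylpropyl on a saturated chain carbon bound to a carbonyl carbon. Within the data shown here, no measured step lengthens a chain in this way. The closest evidence comes from exchanges of the whole group on the same oxygen, and even those stayed modest, as in a 2.5-fold lower number from compound 1 to compound 2 (0.40 log units; beyond the scatter). A step beyond the scatter is therefore not firmly expected, although a slight lean towards a lower number seems reasonable. The expected change is a 1.4-fold lower number from compound 3 to compound 4 (0.14 log units; within the scatter). For compound 4 the estimated value is 13000 nM, with an expected range of 5500 nM to 28000 nM.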

Compound 4, half-maximal inhibitory concentration: 60600 nM
The estimate for compound 4 lay 4.7-fold (0.67 log units) below the measured number; the measured number lies above the stated range.
By their numbers in this assay, from the lowest: compounds 3 and 2 (each within the scatter of the next); then compounds 4 and 1 (each within the scatter of the next).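

In this assay, 1-hydroxy-1-methylpentyl in place of 1-hydroxy-1-methylpropyl on a saturated chain carbon bound to a carbonyl carbon gives the first step read at this place (a 3.4-fold higher number from compound 3 to compound 4 (0.53 log units; beyond the scatter)), so the length of this chain matters and lengthening it here costs activity. The change also takes compound 4 away from the low end of the range (a 2.5-fold higher number from compound 2 to compound 4 (0.39 log units; beyond the scatter)) and leaves it within the scatter of the 2-methoxyethyl compound (a 1.0-fold lower number from compound 1 to compound 4 (0.01 log units; within the scatter)). Nothing available here accounts for this rise.

Among these compounds, with only two chain lengths at this place, it stays open whether the number climbs steadily with length or jumps at one point, which a 1-hydroxy-1-methylbutyl group or a longer chain could settle. Also open, from the compounds shown here alone, is how an amine in place of the hydroxy group would read.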